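Butyl to methylsulfanyl at the aryl ketone: cytotoxicity step

The source may hold more compounds than are shown below. What is called first, only, known or untested is meant among the compounds shown, and "the series" means these compounds.

Compound 1 `O=C(/C=C/c1ccc([N+](=O)[O-])s1)c1ccc(C2CCCCC2)cc1` and compound 2 `CCCCc1ccc(C(=O)/C=C/c2ccc([N+](=O)[O-])s2)cc1` share one core and differ only on the six-membered carbon ring. In an ADME assay on THP-1 cells (Homo sapiens) for cytotoxicity, read by resazurin assay, with a stated time of 72 h (a lower number here means that less compound is tolerated, a higher number that more compound is tolerated), compound 1 sits at a limit of the assay, > 50000 nM. In this assay compound 2 gives 17100 nM, the only number shown in the set. The measured step is an at least 2.9-fold lower number from compound 1 to compound 2 (0.46 log units; beyond the scatter), and its size is bounded by the limit of > 50000 nM in this assay, at which 1 of the 2 values shown sits.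

Compound 3 `CSc1ccc(C(=O)/C=C/c2ccc([N+](=O)[O-])s2)cc1` differs from compound 2 by methylsulfanyl in place of butyl on an aromatic carbon. Going by the values given here, no measured step covers this exchange; the single step of an at least 2.9-fold lower number from compound 1 to compound 2 (0.46 log units; beyond the scatter) concerns cyclohexyl against butyl and runs into a limit, so it gives only loose guidance. In this assay a step of at most modest size is therefore expected, with direction uncertain, and compound 3 is estimated at 25000 nM, within 9000 nM to 60000 nM. The expected step is a 1.5-fold higher number from compound 2 to compound 3 (0.16 log units; within the scatter).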

Compound 3, half-maximal cytotoxic concentration: 8560 nM
For compound 3 the middle estimate is 2.9-fold (0.47 log units) above the measured one; measured number outside the range, below it.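

In this assay, methylsulfanyl in place of butyl on this aromatic carbon gives a 2.0-fold lower number from compound 2 to compound 3 (0.30 log units; within the scatter), so the two groups without a ring are not separated here, even though sulfur enters and the chain shortens. Against the cyclohexyl of compound 1, methylsulfanyl gives an at least 5.8-fold lower number from compound 1 to compound 3 (0.76 log units; beyond the scatter), which makes it the second group without a ring, after butyl, to show a step beyond the scatter, though compound 1 is the only ring-bearing example. The true size of this step stays open: the limit of > 50000 nM in this assay, at which 1 of the 3 values shown sits.

The compounds shown leave open whether a carboxylic acid, an amine or a longer chain at this place would stay close to butyl and methylsulfanyl. They also leave open whether another ring-bearing group, such as cyclopentyl or phenyl, would behave like cyclohexyl.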